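The source may report more compounds than this note shows. Statements on the series, on what has been measured and on what is new or still open speak of the compounds shown alone.

Compound 1 `Cc1cc(C)c(NC(=O)N(Cc2ccc(N3CCN(C)CC3)cc2)C2CCCCCC2)c(C)c1` is the starting point of this account. In a functional assay on a cell-free system (plasma) with sterol O-acyltransferase, Soat (Rattus norvegicus) as the target (a higher number here means that more compound is needed for the effect, a lower number that less compound is needed), compound 1 gives > 1 mg/kg, and that figure is a limit of the assay rather than a measured number. Within the data shown here, the only other compound with a result in this assay is compound 2 `CSc1cc(C)nc(SC)c1NC(=O)N(Cc1ccccc1)Cc1cccc(-c2cnn(C)c2)c1`, which shares no single-point relationship with compound 1. In this assay compound 2 gives > 0.1 mg/kg, which is also a limit. So compound 1 stands on a limit, and the one further value available is a limit too, at the limit of > 0.1 mg/kg in this assay, at which 1 of the 2 values shown sits, and at the limit of > 1 mg/kg in this assay, at which 1 of the 2 values shown sits; neither can be ordered against the other.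

The compound still to be measured is compound 3 `Cc1cc(C)c(NC(=O)N(Cc2ccc(-n3nccn3)cc2)C2CCCCCC2)c(C)c1`. It differs from compound 1 in one place: 2H-1,2,3-triazol-2-yl in place of 4-methylpiperazin-1-yl on an aromatic carbon.

Among the measured compounds shown here, no step between measured compounds is available to anchor this change, so the expectation for this assay is a shift of no size beyond the usual scatter. Compound 3 is accordingly estimated at 2 mg/kg, with a range from 0.7 mg/kg to 6 mg/kg, and the change from compound 1 is expected to be a step that the limit leaves unreadable from compound 1 to compound 3.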

Compound 3, dose for half-maximal effect: > 1 mg/kg
Compound 3 gave a limit, no number (the forecaster's own chance of this, stated with the estimate: 70%); the middle value lies beyond the limit too.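

In this assay compound 3 gives > 1 mg/kg, which is a limit and not a number. Among these compounds, compound 1 also stands on a limit, so no step from compound 1 to compound 3 can be read: the limit of > 1 mg/kg in this assay, at which 2 of the 3 values shown sit. The compounds shown leave open whether 2H-1,2,3-triazol-2-yl in place of 4-methylpiperazin-1-yl changes the dose for half-maximal effect at all.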